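The source may report more compounds than this note shows. Statements on the series, on what has been measured and on what is new or still open speak of the compounds shown alone.

Measured so far in an ADME assay on MT4 cells (Homo sapiens) for cytotoxicity, read by MTT assay, with a stated time of 4 days; a higher number here means that more compound is tolerated, a lower number that less compound is tolerated:
- compound 1 `Cc1c(Cc2c(F)cccc2F)nc(N(C)C(C)C)[nH]c1=O`: 79000 nM
- compound 2 `Cc1c(Cc2c(F)cccc2F)nc(N(C)C2CCCCC2)[nH]c1=O`: > 72000 nM (a limit, not a number)
- compound 3 `Cc1c(Cc2c(F)cccc2F)nc(N2CCCC(C)C2)[nH]c1=O`: > 75000 nM (a limit, not a number)

Compound 3 has no number in this assay, only the limit > 75000 nM. Compound 2 is likewise held only by a limit, (the limit of > 72000 nM in this assay, at which 1 of the 3 values shown sits).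

The next step leads to compound 4 `Cc1c(Cc2c(F)cccc2F)nc(N2CCCCCC2)[nH]c1=O`. The change is azepan-1-yl in place of 3-methylpiperidin-1-yl on an aromatic carbon, the same atoms joined differently, with the seven-membered ring replacing the six-membered one.

For the measured compounds named here, three measured steps bear on this change, and none gives a size: a step that the limit leaves unreadable from compound 1 to compound 3, a step that the two limits leave unreadable from compound 2 to compound 3 and a step that the limit leaves unreadable from compound 1 to compound 2. They show no readable effect of changing this amine group, but they do not show that there is none. Going by the values given here, the only number is that of compound 1 at 79000 nM, and the expectation rests on it.

In this assay no shift beyond the scatter is expected, in either direction. The expected step is a number no higher from compound 3 to compound 4 (the limit leaves the size open). For compound 4 the estimated value is 75000 nM, with an expected range from 40000 nM to 110000 nM. A report as a limit rather than a number would be no surprise.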

Compound 4, half-maximal cytotoxic concentration: > 75000 nM
Compound 4: no number, only a limit; the forecaster's own chance of this, stated with the estimate: 70%; the middle value lies on the limit itself.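

In this assay compound 4 gives > 75000 nM, a limit and not a number. None of the steps joining compound 4 to compound 1, compound 2 and compound 3 can be read. The compounds shown leave open whether changing the amine group on the shared core shifts the tolerated concentration at all, with compound 1 alone holding a number.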